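The source may hold more compounds than are shown below. What is called first, only, known or untested is meant among the compounds shown, and "the series" means these compounds.

Compound 1 `O=c1ccc2cc(OCc3cn(-c4ccccc4)nn3)ccc2o1`, compound 2 `COc1ccc(-n2cc(COc3ccc4oc(=O)ccc4c3)nn2)cc1` and compound 3 `O=c1ccc2cc(OCc3cn(-c4ccccc4[N+](=O)[O-])nn3)ccc2o1` share the same core and differ only in what sits on the phenyl ring. In a functional assay on HL-60 cells (Homo sapiens) for cytotoxicity, read by MTT assay, with a stated time of 48 h (on this read-out lower numbers stand for stronger inhibition and higher numbers for weaker inhibition), compound 1 gives 41600 nM, compound 2 gives 46400 nM and compound 3 gives 44600 nM. On the numbers shown, compound 3 stands second highest of the three: its nearest neighbour is compound 2, with a 1.0-fold lower number from compound 2 to compound 3 (0.02 log units; within the scatter), and its furthest is compound 1, with a 1.1-fold higher number from compound 1 to compound 3 (0.03 log units; within the scatter), so all three sit together within the usual spread of repeated measurements.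

Compound 4 `COc1ccccc1-n1cc(COc2ccc3oc(=O)ccc3c2)nn1` is reached from compound 3 by methoxy in place of nitro on an aromatic carbon. Among the measured compounds shown here, three measured steps bear on this change. Adding nitro gave a 1.1-fold higher number from compound 1 to compound 3 (0.03 log units; within the scatter); adding methoxy, as 4-methoxyphenyl rather than 2-methoxyphenyl, gave a 1.1-fold higher number from compound 1 to compound 2 (0.05 log units; within the scatter); and swapping one substituted ring for the other gave a 1.0-fold lower number from compound 2 to compound 3 (0.02 log units; within the scatter). For the measured compounds named here, every one of these steps lies within the scatter, and no measured step here moves beyond it. The expected step is therefore a 1.0-fold lower number from compound 3 to compound 4 (0.01 log units; within the scatter), meaning no change that the assay could distinguish. Compound 4 is accordingly estimated to give 44000 nM in this assay, with a likely range from 22000 nM to 88000 nM.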

Compound 4, half-maximal inhibitory concentration: 55200 nM
Compound 4: the middle estimate sits 1.3-fold (0.10 log units) below what was measured; measured number inside the range.
By their numbers in this assay, from the lowest: compounds 1, 3, 2 and 4 (each within the scatter of the next).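

Putting methoxy in place of nitro on this aromatic carbon, ortho to a large group, gives a 1.2-fold higher number from compound 3 to compound 4 (0.09 log units; within the scatter) in this assay, so at this place the assay does not tell the two groups apart. The new compound also adds two comparisons: 2-methoxyphenyl in place of 4-methoxyphenyl gives a 1.2-fold higher number from compound 2 to compound 4 (0.08 log units; within the scatter), and methoxy in place of hydrogen gives a 1.3-fold higher number from compound 1 to compound 4 (0.12 log units; within the scatter), so neither moving the methoxy group nor adding it at this place produces a difference that can be read. Nothing available here explains why these four compounds stay so close together.

The compounds shown leave open whether any group on the phenyl ring can move the number beyond the scatter, and an amine, a carboxylic acid or a longer chain such as butoxy at this same place would put that to the test. They also leave open how much a change to the shared core would matter, since all four compounds keep that core and differ only on the phenyl ring.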